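The compounds below may be only part of what the source reports. "The series", "measured", "known", "first", "only" and "open" are said of these compounds alone.

Compound 1, `N#Cc1ccc(C(=O)Nc2ccc(S(=O)(=O)Nc3ccccc3)cc2)c(F)c1`: 229 nM in a functional assay on HEK293 cells for agonist activity at probable G-protein coupled receptor 27 (Homo sapiens), read by a luciferase reporter and beta-arrestin recruitment, with a stated time of 10 min; a lower number here means that less compound is needed, a higher number that more compound is needed for the effect.
Compound 2, `O=C(Nc1ccc(S(=O)(=O)Nc2ncccn2)cc1)c1ccc(Cl)cc1Cl`: > 100000 nM, a limit of this assay rather than a number.
Compound 3, `O=S(=O)(Nc1ccccc1)c1ccc(NS(=O)(=O)c2ccc(Cl)cc2Cl)cc1`: > 100000 nM, again a limit of this assay.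

Compound 1 is therefore the only one of the three with a measured number in this assay; the other two sit at the limit of > 100000 nM in this assay, at which 2 of the 3 values shown sit. Among the measured compounds shown here, no step between two measured compounds that differ in a single place is available, so nothing in the set itself calibrates the size of a change at the carbonyl carbon.

Compound 4, `O=C(Nc1ccc(S(=O)(=O)Nc2ccccc2)cc1)c1ccc(Cl)nc1F`, differs from compound 1 in one place: 6-chloro-2-fluoropyridin-3-yl in place of 4-cyano-2-fluorophenyl on a carbonyl carbon. The 4-cyano-2-fluorophenyl group leaves and the 6-chloro-2-fluoropyridin-3-yl group enters on the carbonyl carbon whose other neighbour is the amide-type nitrogen, while the sulfonamide side is kept as in compound 1.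

The step from compound 1 to compound 4 is expected to be a modest loss, of about a 2.6-fold higher number from compound 1 to compound 4 (0.42 log units; beyond the scatter), somewhat beyond the usual scatter. Compound 4 is accordingly estimated at 600 nM in this assay, with a range from 150 nM to 3000 nM.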

Compound 4, half-maximal effective concentration: 2290 nM
The estimate for compound 4 lay 3.8-fold (0.58 log units) below the measured number; the measured number falls inside the stated range.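

Among the compounds shown here, the replacement of 4-cyano-2-fluorophenyl by 6-chloro-2-fluoropyridin-3-yl on the carbonyl carbon gives a 10-fold higher number from compound 1 to compound 4 (1.00 log units; beyond the scatter), the first single-place step in this assay and so the first measure of how this position responds. Compound 4 still returns a measured number, showing that this replacement does not carry the compound to the limit of the assay: the limit of > 100000 nM in this assay, at which 2 of the 4 values shown sit. The nitrile leaves while a ring nitrogen and a chlorine enter in this one step, and the step does not tell which of these changes carries the loss.

The compounds shown leave open whether a chlorine on the phenyl ring, or a nitrile on the pyridine ring, would stand closer to compound 1. They also leave open how an amine or a carboxylic acid would fare on that ring.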